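Benzyl in place of 2-methoxyphenyl: what to expect

The source may report more compounds than this note shows. Statements on the series, on what has been measured and on what is new or still open speak of the compounds shown alone.

Among the compounds with values here, in a functional assay on Shh Light II cells (Mus musculus) for inhibition, read by a luciferase reporter (a lower number here means a stronger inhibitor, a higher number a weaker inhibitor), compound 1 `O=C(NC1CC[S+]([O-])CC1)N1CCC(c2nc(-c3ccc4ccccc4n3)no2)CC1` gives 850 nM and compound 2 `COc1ccccc1OC(=O)N1CCC(c2nc(-c3ccc4ccccc4n3)no2)CC1` gives 250 nM, so compound 2 holds the lower, stronger number of the two measured so far. Compound 3 `O=C(OCc1ccccc1)N1CCC(c2nc(-c3ccc4ccccc4n3)no2)CC1` has not yet been measured. It carries benzyl in place of 2-methoxyphenyl on an oxygen next to a carbonyl group. Within the data shown here, only one measured step bears on this change, and only loosely: a 3.4-fold lower number from compound 1 to compound 2 (0.53 log units; beyond the scatter). That modest step exchanged a different group, so it hints at the size a change here can reach but gives no direction for this one. Both groups in the new change hold a six-membered aromatic ring of carbon only. In this assay the expected step is a 1.2-fold higher number from compound 2 to compound 3 (0.08 log units; within the scatter), which would lie within the scatter. Compound 3 is estimated at 300 nM, with an expected range of 100 nM to 900 nM.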

Compound 3, half-maximal inhibitory concentration: > 2500 nM
Compound 3: a limit, no number (the forecaster's own chance of this, stated with the estimate: 3%); middle value at least 8.3-fold (0.92 log units) from the limit.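

In this assay, the reading for compound 3 is a limit of the assay and not a number: the limit of > 2500 nM in this assay, at which 1 of the 3 values shown sits.

Benzyl in place of 2-methoxyphenyl on an oxygen next to a carbonyl group still gives an at least 10-fold higher number from compound 2 to compound 3 (1.00 log units; beyond the scatter), so this position separates two groups that each hold a six-membered aromatic ring of carbon only. With an at least 2.9-fold higher number from compound 1 to compound 3 (0.46 log units; beyond the scatter), an aromatic ring in this group does not by itself bring a lower number, and the group with a non-aromatic ring ranks ahead of benzyl here.

Still open, as far as these compounds go, is what matters in 2-methoxyphenyl: its methoxy group, or the ring sitting directly on the oxygen without the methylene link of benzyl. A plain phenyl or a 2-methylphenyl group at this place would help separate these two readings, while the limit leaves the full size of the loss unknown.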